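Ester Analogue with Amino in Place of Nitro

The source may hold more compounds than are shown below. What is called first, only, known or untested is meant among the compounds shown, and "the series" means these compounds.

Measured compounds:
compound 1, `COc1ccc(C(=O)Nc2cc(OC)c(OC)c(OC)c2)cc1[N+](=O)[O-]`: 2000 nM
compound 2, `COc1ccc(C(=O)Nc2cc(OC)c(OC)c(OC)c2)cc1N`: > 100000 nM
compound 3, `COc1ccc(C(=O)Oc2cc(OC)c(OC)c(OC)c2)cc1[N+](=O)[O-]`: > 100000 nM

In a functional assay on HCT-15 cells (Homo sapiens) for antiproliferative activity, read by MTT assay, with a stated time of 72 h (a lower number here means a stronger inhibitor, a higher number a weaker inhibitor), compound 1 gives 2000 nM. Compound 2 gives only a limit of the assay in this assay, > 100000 nM. The step between them, an at least 50-fold higher number from compound 1 to compound 2 (1.69 log units; beyond the scatter), comes with one change, (amino in place of nitro on an aromatic carbon). Compound 3 likewise gives only a limit of the assay in this assay, > 100000 nM. How the core of compound 3 differs from the core of compound 1 is not broken down here.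

Compound 4, `COc1ccc(C(=O)Oc2cc(OC)c(OC)c(OC)c2)cc1N`, has not yet been measured. It differs from compound 3 by amino in place of nitro on an aromatic carbon, and the surroundings of that place are the same as for the change made from compound 1 to compound 2, so it is the same change, made twice among these four compounds. Two of the three values shown already sit at the limit of > 100000 nM in this assay, at which 2 of the 3 values shown sit.

For this assay the expected step from compound 3 to compound 4 is a number no higher from compound 3 to compound 4 (the limit leaves the size open). The expectation rests on the earlier step of the same change, an at least 50-fold higher number from compound 1 to compound 2 (1.69 log units; beyond the scatter). It also rests on compound 3 starting from a value that is itself a limit, > 100000 nM. Compound 4 is therefore estimated at 100000 nM, most likely again reported only as a limit. The expected span for compound 4 runs from 30000 nM to 300000 nM.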

Compound 4, half-maximal inhibitory concentration: > 100000 nM
Compound 4: a limit, no number; the forecaster's own chance of this, stated with the estimate: 95%; the middle value sits exactly at the limit.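

In this assay, for the compounds shown here, compound 4 gives > 100000 nM, a limit of the assay, and the value of compound 3 is also a limit, so no step between compound 3 and compound 4 can be read. The compounds shown leave open whether amino in place of nitro on an aromatic carbon acts on compound 3 as it does on compound 1, since the values gather at one point: the limit of > 100000 nM in this assay, at which 3 of the 4 values shown sit.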